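An Amino Group Added Twice on Related Nucleoside Cores

A few compounds are considered here, and "the series" means these few. Any claim that something is new, unique, unknown or untested is made for them only; others in the source may bear on it.

Measured compounds:
compound 1, `COc1ncnc2c1c(-c1ccoc1)cn2[C@@H]1O[C@H](CO)[C@@H](O)[C@H]1O`, 190 nM
compound 2, `COc1nc(N)nc2c1c(-c1ccoc1)cn2[C@@H]1O[C@H](CO)[C@@H](O)[C@H]1O`, > 20000 nM
compound 3, `O=c1[nH]cnc2c1c(-c1cc3ccccc3o1)cn2[C@@H]1O[C@H](CO)[C@@H](O)[C@H]1O`, > 20000 nM

In a functional assay on K562 cells (Homo sapiens), read by MTT assay, with a stated time of 72 h (a higher number here means a weaker inhibitor, a lower number a stronger inhibitor), compound 1 gives 190 nM. For compound 2 the result in this assay is a limit of the assay, > 20000 nM. The change from compound 1 to compound 2 is amino in place of hydrogen on an aromatic carbon, and it made an at least 100-fold higher number from compound 1 to compound 2 (2.02 log units; beyond the scatter); the value of compound 2 sits at the limit of > 20000 nM in this assay, at which 2 of the 3 values shown sit.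

For compound 3 the result in this assay is likewise a limit, > 20000 nM. How the core of compound 3 differs from that of compound 1 is not broken down here.

Compound 4, `Nc1nc2c(c(-c3cc4ccccc4o3)cn2[C@@H]2O[C@H](CO)[C@@H](O)[C@H]2O)c(=O)[nH]1`, is made from compound 3 by amino in place of hydrogen on an aromatic carbon. This is the same kind of change as from compound 1 to compound 2, though the surroundings differ: in compound 1 the place is meta to a methoxy group (2 heavy atoms), in compound 3 meta to a group of 1 heavy atom. Since compound 3 already sits at a limit and the earlier step was large, compound 4 is expected to remain at a limit, with an estimated step that the limit leaves unreadable from compound 3 to compound 4. The estimate for compound 4 in this assay is 40000 nM, between 20000 nM and 200000 nM.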

Compound 4, half-maximal inhibitory concentration: > 20000 nM
Compound 4: no number, only a limit; the forecaster's own chance of this, stated with the estimate: 90%; the middle value lies beyond the limit too.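

In this assay compound 4 gives > 20000 nM, which is a limit of the assay. Within the data shown here, compound 3 gives > 20000 nM, likewise a limit, so no step from compound 3 to compound 4 can be read. The compounds shown leave open whether amino in place of hydrogen changes the result on the core of compound 3 as it does on the core of compound 1.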